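This account rests on a few compounds, and the source may have more. Where it says the series, first, only, none or still open, it means among the compounds named here.

Three analogues of the shared core have so far been run in a functional assay on MCF7 cells (Homo sapiens) for cytotoxicity, read by MTT assay, with a stated time of 72 h; on this read-out lower numbers stand for stronger inhibition and higher numbers for weaker inhibition. Compound 1 `COc1ccccc1Nc1nc(SCc2ccc(C(F)(F)F)cc2)nc2ccccc12` returns only a limit of the assay, > 50000 nM. Compound 2 `COc1ccc(Nc2nc(SCc3ccc(C(F)(F)F)cc3)nc3ccccc23)cc1` gives 47200 nM in this assay. Compound 3 `COc1ccc(Nc2nc(SCc3ccc(C(F)(F)F)cc3)nc3ccccc23)c(OC)c1` again returns only a limit, > 50000 nM, so compound 3 stands among the values at the limit of > 50000 nM in this assay, at which 2 of the 3 values shown sit. The step of an at least 1.0-fold lower number from compound 1 to compound 2 (0.02 log units; that floor lies within the scatter) stays within the scatter, as does an at least 1.0-fold higher number from compound 2 to compound 3 (0.02 log units; that floor lies within the scatter); the pair a step that the two limits leave unreadable from compound 1 to compound 3 cannot be read, both ends being limits. Compound 4 `COc1cc(Nc2nc(SCc3ccc(C(F)(F)F)cc3)nc3ccccc23)cc(OC)c1` differs from compound 3 by 3,5-dimethoxyphenyl in place of 2,4-dimethoxyphenyl on a nitrogen on an aromatic ring. Among the measured compounds shown here, every measured step so far moves methoxy groups around the same phenyl ring on the nitrogen and none of them shows a change beyond the scatter, so no shift beyond the scatter is expected from this rearrangement either: the expected step is a number no higher from compound 3 to compound 4 (the limit leaves the size open), with a fair chance that this assay once more reports only a limit. Compound 4 is accordingly estimated at 50000 nM, within a range of 20000 nM to 120000 nM.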

Compound 4, half-maximal inhibitory concentration: 6990 nM
For compound 4 the middle estimate is 7.2-fold (0.85 log units) above the measured one; measured number below the stated range.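

In this assay, among the compounds shown here, the arrangement of the methoxy groups on the phenyl ring on the nitrogen now proves to matter, which the earlier compounds could not show: with the same atoms joined differently, 3,5-dimethoxyphenyl in place of 2,4-dimethoxyphenyl gives an at least 7.1-fold lower number from compound 3 to compound 4 (0.85 log units; beyond the scatter). For the compounds shown here, the 3,5-dimethoxyphenyl group also separates from the single methoxy groups, with a 6.8-fold lower number from compound 2 to compound 4 (0.83 log units; beyond the scatter) and an at least 7.1-fold lower number from compound 1 to compound 4 (0.85 log units; beyond the scatter). The steps starting at compound 1 and compound 3 are floors and not full sizes, because each of those two compounds returns only a limit of the assay: the limit of > 50000 nM in this assay, at which 2 of the 4 values shown sit.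

On these data alone, whether an ethoxy, hydroxyl or amine group in place of methoxy on this ring would keep the lower number stays open. Also open, as far as these compounds go, is whether the same change holds with a nitrile in place of trifluoromethyl on the other aromatic ring.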